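This account rests on a few compounds, and the source may have more. Where it says the series, first, only, none or still open, it means among the compounds named here.

Among the measured compounds shown here, in an ADME assay on microsomes from liver (Rattus norvegicus) for metabolic stability (a higher number here means that the compound lasts longer, a lower number that the compound disappears faster), compound 1 (`CC(C)C(Cc1nnc[nH]1)c1ccc(-c2ccc3cccc(F)c3c2)[nH]c1=O`) gives 0.1 h and so stands lowest of the three numbers measured so far. Compound 2 (`CC(C)[C@H](C[C@H]1CCNC1=O)c1ccc(-c2ccc3cccc(F)c3c2)[nH]c1=O`) reaches 0.227 h and compound 3 (`CCC(CC)(c1nnc[nH]1)c1ccc(-c2ccc3cccc(F)c3c2)[nH]c1=O`) reaches 0.925 h in the same test, and both lie above compound 1 by more than the usual scatter of repeat measurements. No two of these compounds count as differing in just one place, so no measured step can guide the next prediction directly.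

The next compound to be tested is compound 4 (`CC(C)C(c1cnc(N)s1)c1ccc(-c2ccc3cccc(F)c3c2)[nH]c1=O`). It keeps the core of compound 1, but 2-amino-1,3-thiazol-5-yl takes the place of (4H-1,2,4-triazol-3-yl)methyl on a saturated chain carbon bound to an aromatic carbon and a saturated chain carbon (2-amino-1,3-thiazol-5-yl in place of (4H-1,2,4-triazol-3-yl)methyl on a saturated chain carbon bound to an aromatic carbon and a saturated chain carbon).

The basis for a forecast is thin. Compound 1 at 0.1 h already sits at the bottom of the measured numbers, which leaves more of the observed range above it than below it. Only a small upward move is therefore expected, an estimated 1.8-fold higher number from compound 1 to compound 4 (0.26 log units; within the scatter) that would not clearly stand beyond the scatter. Compound 4 is estimated at 0.18 h in this assay (expected range 0.07 h to 0.5 h).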

Compound 4, half-life: 0.0983 h
The estimate for compound 4 lay 1.8-fold (0.26 log units) above the measured number; the range from low to high includes it.
By their numbers in this assay, from the lowest: compounds 4 and 1 (each within the scatter of the next); then compound 2; then compound 3.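

With 2-amino-1,3-thiazol-5-yl in place of (4H-1,2,4-triazol-3-yl)methyl on a saturated chain carbon bound to an aromatic carbon and a saturated chain carbon, this assay shows a 1.0-fold lower number from compound 1 to compound 4 (0.01 log units; within the scatter) and so does not tell the two compounds apart. Among the compounds shown here, this is the first pair here that differs in only one place, and it gives a first direct reading of this position: exchanging these two groups, which have the same number of heavy atoms, gives no difference beyond the scatter, even though the entering ring carries sulfur and the leaving group has a methyl link. Nothing available explains why the two groups read alike in this test.

For the compounds shown here, this single pair covers only two groups at one position, so it cannot show whether the position as a whole has little bearing on the half-life or whether these two groups merely happen to give similar numbers. As far as these compounds go, a carboxylic acid or a longer chain on the same carbon, with the rest of compound 1 kept, would test that question, and its outcome remains open.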